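The source may report more compounds than this note shows. Statements on the series, on what has been measured and on what is new or still open speak of the compounds shown alone.

Measured in a functional assay on MCF7 cells (Homo sapiens) for inhibition, read by CCK-8 assay, with a stated time of 72 h; on this read-out lower numbers stand for stronger inhibition and higher numbers for weaker inhibition:
- compound 1 `O=C(/C=C/c1cccnc1)NCCCc1ccc(S(=O)(=O)Nc2ccccc2)cc1`: 4120 nM
- compound 2 `O=C(/C=C/c1cccnc1)NCCCc1cccc(S(=O)(=O)Nc2ccccc2)c1`: 142 nM
- compound 3 `O=C(/C=C/c1cccnc1)NCCCCCCc1cccc(S(=O)(=O)Nc2ccccc2)c1`: 0.63 nM

Compound 3, at 0.63 nM, has the lowest number of the three, and its gaps to compound 2 and compound 1 both lie beyond the scatter. Compound 4 `Cc1ccc(NS(=O)(=O)c2cccc(CCCCCCNC(=O)/C=C/c3cccnc3)c2)cc1` differs from compound 3 in one place: methyl in place of hydrogen on an aromatic carbon. Methyl replaces hydrogen on an aromatic carbon, para to a large group, turning phenyl into 4-methylphenyl. Among the measured compounds shown here, no measured compound carries a group on that phenyl, so the data offer no direct precedent. No step beyond the scatter is expected in this assay, with only a slight lean towards a higher number. The estimated step is a 1.4-fold higher number from compound 3 to compound 4 (0.15 log units; within the scatter). For compound 4 the estimated value is 0.9 nM, with an expected range from 0.2 nM to 5 nM.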

Compound 4, half-maximal inhibitory concentration: 1.97 nM
Compound 4: middle estimate off by 2.2-fold (0.34 log units), on the low side, within the range that was stated.
By their numbers in this assay, from the lowest: compound 3; then compound 4; then compound 2; then compound 1.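

In this assay, turning phenylsulfamoyl into (4-methylphenyl)sulfamoyl gives a 3.1-fold higher number from compound 3 to compound 4 (0.50 log units; beyond the scatter) and so shows that this phenyl is sensitive to substitution, though only modestly. A single methyl on this aromatic carbon leaves compound 4 at 1.97 nM and does not remove the activity. No evidence here bears on the reason for this step.

As far as these compounds go, whether a methoxy group, an amine or a carboxylic acid at this carbon would move the number further remains open. So does whether methyl would give a similar step on the shorter chain of compound 2.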